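This account rests on a few compounds, and the source may have more. Where it says the series, first, only, none or still open, it means among the compounds named here.

Going by the values given here, compound 2 `COc1ccc(C(=O)c2ccc([N+](=O)[O-])cc2)cc1OC(=O)CCC(=O)OC[C@@H]1C=C[C@H](n2cc(C)c(=O)[nH]c2=O)O1` gives 24000 nM in a functional assay on HepG2 cells (Homo sapiens) for antiproliferative activity, read by MTT assay, with a stated time of 48 h (a lower number here means a stronger inhibitor, a higher number a weaker inhibitor), the higher of the two numbers so far; compound 1 `COc1cccc(C(=O)c2ccc(OC)c(OC(=O)CCC(=O)OC[C@@H]3C=C[C@H](n4cc(C)c(=O)[nH]c4=O)O3)c2)c1` gives 3150 nM in this assay. Among the compounds with values here, the single measured step, a 7.6-fold higher number from compound 1 to compound 2 (0.88 log units; beyond the scatter), came with 4-nitrophenyl in place of 3-methoxyphenyl on a carbonyl carbon. Compound 3 `COc1ccc(C(=O)c2ccc(F)cc2)cc1OC(=O)CCC(=O)OC[C@@H]1C=C[C@H](n2cc(C)c(=O)[nH]c2=O)O1` differs from compound 2 by fluoro in place of nitro on an aromatic carbon. Within the data shown here, that one step bears on the change only in part: it shows that the nitro-bearing ring went with the weaker number, but nothing measured separates the loss of nitro from the gain of fluoro, and no compound in hand carries a fluoro. A partial return toward the number of compound 1 is therefore expected, with wide uncertainty, and the expected step is a 2.7-fold lower number from compound 2 to compound 3 (0.43 log units; beyond the scatter). Compound 3 is estimated at 9000 nM, with a range from 2500 nM to 30000 nM.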

Compound 3, half-maximal inhibitory concentration: 20300 nM
For compound 3 the middle estimate is 2.3-fold (0.35 log units) below the measured one; the range from low to high includes it.
By their numbers in this assay, from the lowest: compound 1; then compounds 3 and 2 (each within the scatter of the next).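

In this assay, fluoro in place of nitro gives a 1.2-fold lower number from compound 2 to compound 3 (0.07 log units; within the scatter), so the two groups cannot be told apart at this position on the ring. The weaker number of compound 2 is thus not specific to nitro: a 6.4-fold higher number from compound 1 to compound 3 (0.81 log units; beyond the scatter), and compound 1, with its 3-methoxyphenyl, stays apart from both the 4-nitrophenyl and the 4-fluorophenyl compounds. Nothing available explains this difference.

The compounds shown do not settle whether the lower number of compound 1 goes with the methoxy group itself or with its place on the ring, since neither a 4-methoxyphenyl nor an unsubstituted phenyl appears among them. Nor do they show how an amine or a carboxylic acid in place of fluoro would read.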